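Thiazolyl ketone sulfides: chloro to hydrogen on the aryl ring

The source may report more compounds than this note shows. Statements on the series, on what has been measured and on what is new or still open speak of the compounds shown alone.

The series shares a thiazolyl ketone linked through a sulfur to a nitrile-bearing heterocycle, and is read in a functional assay on U-87MG ATCC cells for antiproliferative activity against U-87 MG (Homo sapiens), read by MTT assay, with a stated time of 48 h, tested at 10 uM; a lower number here means a stronger effect, a higher number a weaker effect of the compound at the concentration tested. Compound 1 `COc1ccc(-c2nc(SCC(=O)c3sc(-c4ccccc4)nc3C)[nH]c(=O)c2C#N)cc1` gives 90.4%. Compound 3 `COc1ccc(-c2nc(SCC(=O)c3sc(-c4ccc(Cl)cc4)nc3C)[nH]c(=O)c2C#N)cc1` gives 88.3%. Compound 2 `Cc1nc(-c2ccccc2)sc1C(=O)CSc1nc(N)c(C#N)c(-c2ccc(Cl)cc2)n1` gives 58.8%, the lowest of the three numbers and beyond the scatter from both others, so compound 2 shows the strongest effect at this concentration among the measured compounds. The difference between the core of compound 2 and the core of compound 3 is not broken down here.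

Compound 4 `Cc1nc(-c2ccccc2)sc1C(=O)CSc1nc(N)c(C#N)c(-c2ccccc2)n1` has not yet been measured in this assay. It is related to compound 2 by hydrogen in place of chloro on an aromatic carbon. The same change, measured, is seen from compound 3 to compound 1 as hydrogen in place of chloro on an aromatic carbon, and there it produced a number 2.1 percentage points higher from compound 3 to compound 1 (within the scatter). Both place lines read alike, so it is the same change on a different core.

Among the measured compounds shown here, on that basis the step from compound 2 to compound 4 is expected to be small, a number 2.2 percentage points higher from compound 2 to compound 4 (within the scatter), resting on the step from compound 3 to compound 1 being within the scatter; the pattern rests on a single measured pair, and no other measured compound exists to test it. Compound 4 is therefore expected to give about 61% in this assay, with a likely range from 46% to 78%.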

Compound 4, a percentage reported as activity, at one concentration (the size of the read-out at that concentration, not a potency): 93%
Beside the measured number, compound 4's estimate is 32 percentage points below it; measured number above the stated range.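

In this assay, going from 4-chlorophenyl to phenyl on the core of compound 2 gives a number 34.2 percentage points higher from compound 2 to compound 4 (beyond the scatter), so on this core the stronger effect at the tested concentration is lost with the chloro, and removing the chloro does not act as a fixed increment across the series. Among the compounds shown here, the size of the step depends on the pair in which it is read: the same change on two cores in this assay, a number 2.1 percentage points higher (within the scatter) from compound 3 to compound 1 and a number 34.2 percentage points higher (beyond the scatter) from compound 2 to compound 4, 32.1 percentage points apart, beyond the scatter of two such steps The two pairs differ in their cores and also in which aryl ring carries the chloro, so these data do not show which of the two differences sets the size of the step, nor do they give any reason for it, and with only two pairs they support no general rule.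

Open, on these data alone, is whether the effect in compound 2 is specific to chloro or would also appear with fluoro, bromo or trifluoromethyl in the same place on that ring. Also open, as far as these compounds go, is whether the core of compound 1 would respond to a chloro on its other aryl ring, and how compound 2 would rank as a potency, since a single concentration gives only the size of the read-out.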